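The compounds below may be only part of what the source reports. "The series", "measured", "known", "first", "only" and "open" are said of these compounds alone.

Measured compounds:
- compound 1, `C/C(=C\c1cc(-c2ccc(F)cc2)co1)C(N)=O`: in a functional assay on HeLa cells (Homo sapiens) for cytotoxicity, read by CCK-8 assay, with a stated time of 24 h (a lower number here means a stronger inhibitor, a higher number a weaker inhibitor), compound 1 gives 11800 nM.
- compound 2, `C/C(=C\c1cc(C2=CCCCC2)co1)C(N)=O`: compound 2 reaches only the limit > 50000 nM, not a number.
- compound 3, `C/C(=C\c1cc(-c2ccc(C)cc2)cs1)C(N)=O`: compound 3 likewise reaches only the limit > 50000 nM, not a number.

Compound 3 therefore stands at the upper end of what this assay reports, together with compound 2, at the limit of > 50000 nM in this assay, at which 2 of the 3 values shown sit. Only compound 1 is given as a number, and it sits far from the region where strong inhibitors would be found. Going by the values given here, no single-point step between measured compounds is available, so no measured change in this assay can be taken as a guide for the next compound.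

Compound 4, `C/C(=C\c1cc(-c2ccc(S(C)(=O)=O)cc2)cs1)C(N)=O`, is compound 3 with methylsulfonyl in place of methyl on an aromatic carbon. Nothing in the three measured compounds tells how a change of this kind moves the read-out in this assay; the two closest points, compound 2 and compound 3, are both limits and carry no direction.

The expectation for compound 4 is that it stays in the same weak region as compound 3, with a step of an at least 1.1-fold lower number from compound 3 to compound 4 (0.04 log units; that floor lies within the scatter) that is likely no more than the usual scatter. Compound 4 is estimated at 45000 nM, in the range 12000 nM to 100000 nM, with a good chance that only a limit is reported.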

Compound 4, half-maximal inhibitory concentration: > 50000 nM
Compound 4: no number, only a limit; the forecaster's own chance of this, stated with the estimate: 60%; middle value at least 1.1-fold (0.04 log units) from the limit.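

Compound 4 gives > 50000 nM in this assay, a limit and not a number. Compound 3 also stands at a limit, so no step can be read from compound 3 to compound 4. The compounds shown leave open whether methylsulfonyl in place of methyl on an aromatic carbon moves the read-out at all, and in which direction.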